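Thioether linker in place of the aryloxy linker of compound 1

The source may hold more compounds than are shown below. What is called first, only, known or untested is meant among the compounds shown, and "the series" means these compounds.

Compound 1 `O=C(O)Cc1sc(COc2ccc(Cl)cc2)nc1-c1ccc(Cl)cc1` gives 32 nM in an in vitro assay on HEK385-7 cells for displacement of a labelled ligand from prostaglandin D2 receptor 2 (Homo sapiens) (on this read-out lower numbers stand for stronger inhibition and higher numbers for weaker inhibition), the lowest of the three numbers at hand. Compound 3 `O=C(O)Cc1sc(C(c2ccccc2)c2ccc(Cl)cc2)nc1-c1ccc(Cl)cc1` gives 45 nM, a number within the scatter of that of compound 1, so no order between the two is claimed. Compound 2 `O=C(O)Cc1sc(C(c2ccc(F)cc2)c2ccc(F)cc2)nc1-c1ccnc(N2CCCC2)c1` gives 230 nM, which lies beyond the scatter from compound 1. For the measured compounds named here, no two measured compounds differ in a single place, so no measured step exists in this set.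

Compound 4 `O=C(O)Cc1sc(CSc2ccccc2)nc1-c1ccc(Cl)cc1` has not been measured. It differs from compound 1 as follows: phenylsulfanyl in place of 4-chlorophenoxy on a saturated chain carbon bound to an aromatic carbon. The chlorine of the leaving group does not return. Without a measured step to lean on, a small move toward a higher number is expected, possibly within the scatter, and a 1.9-fold higher number from compound 1 to compound 4 (0.27 log units; within the scatter) is the expected step. Compound 4 is expected to give 60 nM in this assay, within 20 nM to 180 nM.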

Compound 4, half-maximal inhibitory concentration: 250 nM
Beside the measured number, compound 4's estimate is 4.2-fold (0.62 log units) below it; measured number above the stated range.
By their numbers in this assay, from the lowest: compounds 1 and 3 (each within the scatter of the next); then compounds 2 and 4 (each within the scatter of the next).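

At this place, on a saturated chain carbon bound to an aromatic carbon, the group matters in this assay: phenylsulfanyl in place of 4-chlorophenoxy gives a 7.8-fold higher number from compound 1 to compound 4 (0.89 log units; beyond the scatter). The step appears although the entering group keeps the six-membered aromatic ring of carbon only and the same count of hydrogen-bond acceptors. No measurement at hand explains this step.

Going by these compounds, the change swaps the ring-bound oxygen for sulfur and removes the chlorine together, so the share of each remains open. Phenoxy or 4-chlorophenylsulfanyl at this place would separate the two.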